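Chain shortening in the hydroxyalkyl ether series

The compounds below may be only part of what the source reports. "The series", "measured", "known", "first", "only" and "open" are said of these compounds alone.

Compound 2 `O=c1c(-c2ccc(O)cc2)coc2cc(OCCCCCCCCCO)ccc12` stands highest of the two numbers measured in an assay (Cricetulus griseus) for inhibition of aldehyde dehydrogenase, mitochondrial (Homo sapiens) (a higher number here means a weaker inhibitor, a lower number a stronger inhibitor), giving 700 nM; compound 1 `O=c1c(-c2ccc(O)cc2)coc2cc(OCCOCCOCCO)ccc12` gives 40 nM in this assay. The step of an 18-fold higher number from compound 1 to compound 2 (1.24 log units; beyond the scatter) is large. Compound 3 `O=c1c(-c2ccc(O)cc2)coc2cc(OCCCCCCO)ccc12` differs from compound 2 by hydroxy in place of 3-hydroxypropyl on a saturated chain carbon, six bonds along the chain from an oxygen on an aromatic ring. Among the measured compounds shown here, that measured step exchanged ether oxygens for chain carbons at roughly constant chain length, so it bears only loosely on a pure shortening; no measured pair tests chain length alone. A step within the scatter is therefore expected, with a 1.8-fold lower number from compound 2 to compound 3 (0.24 log units; within the scatter). Compound 3 is estimated at 400 nM, range 90 nM to 1800 nM.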

Compound 3, half-maximal inhibitory concentration: 120 nM
Compound 3: middle estimate off by 3.3-fold (0.52 log units), on the high side; low and high end bracket the measured number.
By their numbers in this assay, from the lowest: compound 1; then compound 3; then compound 2.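

Hydroxy in place of 3-hydroxypropyl gives a 5.8-fold lower number from compound 2 to compound 3 (0.77 log units; beyond the scatter) in this assay, so chain length alone moves the number at this position in the all-carbon series. Shortening does not fully close the gap to the ether chain: 4-hydroxybutyl in place of 2-(2-hydroxyethoxy)ethoxy still gives a 3.0-fold higher number from compound 1 to compound 3 (0.48 log units; beyond the scatter) between these two compounds. No measurement available here explains either step.

Still open, as far as these compounds go, is whether the ether chain of compound 1 responds to shortening in the same way, and how an amine or a carboxylic acid in place of the hydroxy would read.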